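Removing the Fluoro on the Way to Compound 4

The compounds below may be only part of what the source reports. "The series", "measured", "known", "first", "only" and "open" are said of these compounds alone.

Compound 1 `COc1cc(OC)cc(-c2ccc(-n3cc(-c4cccc(C(=O)O)c4)nn3)cc2)c1`: 92%
Compound 2 `COc1cccc(-c2ccc(-n3cc(-c4cccc(C(=O)O)c4)nn3)cc2)c1OC`: 75%
Compound 3 `COc1ccc(F)c(-c2ccc(-n3cc(-c4cccc(C(=O)O)c4)nn3)cc2)c1`: 93%

In an ADME assay on microsomes from liver (Mus musculus) for metabolic stability, with a stated time of 1 h (on this read-out higher numbers stand for a more stable compound and lower numbers for a less stable compound), compound 3 holds the highest number of the three, though compound 1 lies within the scatter of it, as a number 1 percentage points higher from compound 1 to compound 3 (within the scatter) shows, while compound 2 lies clearly under it, as a number 18 percentage points higher from compound 2 to compound 3 (beyond the scatter) shows. Compound 4 `COc1cccc(-c2ccc(-n3cc(-c4cccc(C(=O)O)c4)nn3)cc2)c1` differs from compound 3 in one place: hydrogen in place of fluoro on an aromatic carbon. Among the measured compounds shown here, no measured step removes a fluoro outright. The nearest is a number 1 percentage points higher from compound 1 to compound 3 (within the scatter), where a fluoro took the place of a methoxy without a change beyond the scatter, which suggests a small step. Compound 4 is therefore expected to stay high, with a number 7 percentage points lower from compound 3 to compound 4 (within the scatter), giving an estimate of 86% in a range from 68% to 98%.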

Compound 4, percent of the compound remaining: 91%
For compound 4 the middle estimate is 5 percentage points below the measured one, and the stated range covers the measured number.
By their numbers in this assay, from the lowest: compound 2; then compounds 4, 1 and 3 (each within the scatter of the next).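

In this assay the fluoro ortho to a large group and para to a methoxy group can go without a change beyond the scatter, with a number 2 percentage points lower from compound 3 to compound 4 (within the scatter) on this read-out. The second methoxy of the 3,5-dimethoxyphenyl group can also give way to hydrogen, with a number 1 percentage points lower from compound 1 to compound 4 (within the scatter) here, whereas the same kind of change from the 2,3-dimethoxyphenyl group gives a number 16 percentage points higher from compound 2 to compound 4 (beyond the scatter) and so depends on where the methoxy sits. Still open, on these data alone, is whether a chlorine, a nitrile or an amine at the fluoro position would keep the number as high. Every compound shown also keeps a methoxy, so the effect of removing the last one stays open. Nothing in hand explains any of these steps.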